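The source may report more compounds than this note shows. Statements on the series, on what has been measured and on what is new or still open speak of the compounds shown alone.

In a physicochemical assay for solubility, using the shake flask method, measured as kinetic solubility, with a stated time of 2 h, at pH 7.4 (on this read-out higher numbers stand for higher solubility and lower numbers for lower solubility), compound 1 (`O=C(Nc1ccccc1)c1cc(N2CCc3ccccc3C2)ncn1`) gives < 5000 nM, which is a limit of the assay and not a number. Compound 2 (`CN(Cc1ccc(F)cc1)c1cc(C(=O)Nc2ccccc2)ncn1`) gives < 5000 nM, also only a limit. Compound 3 (`CN(Cc1ccc(C(F)(F)F)cc1)c1cc(C(=O)Nc2ccccc2)ncn1`) gives < 5000 nM, again a limit. Among the measured compounds shown here, compound 2 therefore has no exact number, and the whole series so far comes down to the limit of < 5000 nM in this assay, at which 3 of the 3 values shown sit.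

Compound 4 (`CN(Cc1ccccc1Cl)c1cc(C(=O)Nc2ccccc2)ncn1`) departs from compound 2 in one place: 2-chlorophenyl in place of 4-fluorophenyl on a saturated chain carbon bound to a nitrogen on an aromatic ring. In words, 2-chlorophenyl stands in place of 4-fluorophenyl on a saturated chain carbon bound to a nitrogen on an aromatic ring. For the measured compounds named here, the only measured step that bears on this change is a step that the two limits leave unreadable from compound 2 to compound 3, with trifluoromethyl in place of fluoro on an aromatic carbon. That step offers no size to carry over, so no change beyond the usual scatter is expected in this assay, and no direction is favoured. The expected step is a step that the limit leaves unreadable from compound 2 to compound 4. Compound 4 is estimated at 3000 nM, within an expected range from 1000 nM to 6000 nM. The likeliest report for it is once more only a limit.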

Compound 4, solubility: < 5000 nM
Compound 4: no number, only a limit; the forecaster's own chance of this, stated with the estimate: 85%; the middle value does not contradict the limit.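

Among the compounds shown here, compound 2 and compound 4 each give only a limit of the assay and not a number, so no step between them can be read: the limit of < 5000 nM in this assay, at which 4 of the 4 values shown sit. The compounds shown leave open what exact solubility any of them has in this assay and whether 4-fluorobenzyl and 2-chlorobenzyl differ there at all.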